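A few compounds are considered here, and "the series" means these few. Any claim that something is new, unique, unknown or untested is made for them only; others in the source may bear on it.

Within the data shown here, compound 1 `NC/C(=C\F)COc1ccccc1` sits at the higher of the two numbers so far: in an assay on isolated protein for inhibition of Amine oxidase [flavin-containing] B (Homo sapiens) (a higher number here means a weaker inhibitor, a lower number a stronger inhibitor), compound 1 gives 13 nM. Among the measured compounds shown here, its only measured neighbour is compound 2 `NCC(=CF)COc1ccccc1`, which in this assay gives 9 nM; the step of a 1.4-fold lower number from compound 1 to compound 2 (0.16 log units; within the scatter) rests on the fact that one of compounds 1 and 2 is drawn with a defined configuration and the other without, at the place where they differ and on nothing else in the structure. Compound 3 `Cc1ccccc1OC/C(=C/F)CN` carries a change of another kind: methyl in place of hydrogen on an aromatic carbon. For the measured compounds named here, no measured step touches an aromatic carbon of the core, so the step from compound 1 to compound 2 says nothing about this change, and the one step recorded lies within the scatter in any case. The expectation for compound 3 is therefore a step of about a 1.2-fold higher number from compound 1 to compound 3 (0.06 log units; within the scatter), with neither direction favoured beyond the scatter. Compound 3 is estimated at 15 nM in this assay, between 5 nM and 50 nM.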

Compound 3, half-maximal inhibitory concentration: 3 nM
For compound 3 the middle estimate is 5.0-fold (0.70 log units) above the measured one; measured number outside the range, below it.
By their numbers in this assay, from the lowest: compound 3; then compounds 2 and 1 (each within the scatter of the next).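

In this assay, among these compounds, methyl in place of hydrogen on an aromatic carbon, ortho to a group of 7 heavy atoms, gives a 4.3-fold lower number from compound 1 to compound 3 (0.64 log units; beyond the scatter), the only step so far that lies beyond the scatter. This shows that the six-membered aromatic ring of carbon only accepts a single added carbon at this position without loss in this assay, and that a change here moves the number in the direction of a stronger inhibitor, which the comparison of the drawn configurations could not show. The information at hand on these compounds does not bear on the origin of this step.

Open, on these data alone, is whether ethyl, methoxy or chlorine at this position would give a step in the same direction. Equally open, as far as these compounds go, is whether methyl on another carbon of the same ring would do so.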